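Replacing Cyclohexyl on an Amide-Type Nitrogen

This account rests on a few compounds, and the source may have more. Where it says the series, first, only, none or still open, it means among the compounds named here.

Among the compounds with values here, in a functional assay on MCF7 cells (Homo sapiens) for antiproliferative activity, read by MTT assay, with a stated time of 72 h (on this read-out higher numbers stand for weaker inhibition and lower numbers for stronger inhibition), compound 2 `O=C(Nc1ccc(Nc2nccc(NC3CCCC3)n2)cc1)NC1CCCCC1` gives 19200 nM and stands highest of the two numbers so far, whereas compound 1 `O=C(Nc1ccc(Nc2nccc(NC3CCCC3)n2)cc1)Nc1ccc(Cl)c(C(F)(F)F)c1` gives 2330 nM in comparison. Within the data shown here, compound 3 `O=C(Nc1ccc(Nc2nccc(NC3CCCC3)n2)cc1)Nc1cccc(C(F)(F)F)c1` has 3-(trifluoromethyl)phenyl in place of cyclohexyl on an amide-type nitrogen as its one change. Among the measured compounds shown here, the only measured step bearing on this is an 8.2-fold higher number from compound 1 to compound 2 (0.92 log units; beyond the scatter) and it falls at the same nitrogen, so a move to a lower number, of similar or slightly smaller size, is expected in this assay on leaving cyclohexyl. The expected step is a 4.3-fold lower number from compound 2 to compound 3 (0.63 log units; beyond the scatter) in size. For compound 3 the estimate is 4500 nM with 1800 nM to 11000 nM as its range.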

Compound 3, half-maximal inhibitory concentration: 5180 nM
The estimate for compound 3 lay 1.2-fold (0.06 log units) below the measured number, and the stated range covers the measured number.
By their numbers in this assay, from the lowest: compound 1; then compound 3; then compound 2.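

In this assay, 3-(trifluoromethyl)phenyl in place of cyclohexyl on the amide-type nitrogen gives a 3.7-fold lower number from compound 2 to compound 3 (0.57 log units; beyond the scatter), so a lower number at this position does not depend on the chloro group. Hydrogen in place of chloro on the aromatic carbon still gives a 2.2-fold higher number from compound 1 to compound 3 (0.35 log units; beyond the scatter), which shows that the chloro group also contributes to the lower number of compound 1. Nothing available explains either step. Going by these compounds, whether the trifluoromethyl group is needed remains open, as an unsubstituted phenyl ring would test. On these data alone, a carboxylic acid or an amine on the aromatic ring also remains untested here.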